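The source may report more compounds than this note shows. Statements on the series, on what has been measured and on what is new or still open speak of the compounds shown alone.

Compound 1 `CCCOc1ccc2[nH]c(-c3ccccc3)c(C3=C(Br)C(=O)NC3=O)c2c1`, compound 2 `CCCCOc1ccc2[nH]c(-c3ccccc3)c(C3=C(Br)C(=O)NC3=O)c2c1` and compound 3 `CCCCCc1ccc2[nH]c(-c3ccccc3)c(C3=C(Br)C(=O)NC3=O)c2c1` share one core and have been measured in a physicochemical assay for lipophilicity; on this read-out lower numbers stand for lower lipophilicity and higher numbers for higher lipophilicity. Compound 1 gives 3.16, compound 2 gives 3.42 and compound 3 gives 4.07. Compound 2 stands second highest of the three: its nearest neighbour is compound 1, with a number 0.26 log units higher from compound 1 to compound 2 (within the scatter), and its furthest is compound 3, with a number 0.65 log units higher from compound 2 to compound 3 (beyond the scatter); a number 0.91 log units higher from compound 1 to compound 3 (beyond the scatter) runs the same way. Compound 4 `CCCCOc1ccc2[nH]c(-c3cccc(OC)c3)c(C3=C(Br)C(=O)NC3=O)c2c1` carries methoxy in place of hydrogen on an aromatic carbon, meta to a large group. Among the compounds with values here, no measured step touches that ring; the one addition of a single carbon, a number 0.26 log units higher from compound 1 to compound 2 (within the scatter), stayed within the scatter, so in this assay no step beyond the scatter is expected. Compound 4 is estimated at 3.4, between 3.1 and 3.7, which means an expected a number 0.02 log units lower from compound 2 to compound 4 (within the scatter).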

Compound 4, partition coefficient: 3.46
Compound 4: the middle estimate sits 0.06 log units below what was measured; the measured number falls inside the stated range.
By their numbers in this assay, from the lowest: compounds 1, 2 and 4 (each within the scatter of the next); then compound 3.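

Within the data shown here, this is the first reading on the 2-phenyl ring: in this assay, phenyl to 3-methoxyphenyl gives a number 0.04 log units higher from compound 2 to compound 4 (within the scatter), so on this aromatic carbon methoxy in place of hydrogen leaves the read-out of compound 4 level with that of compound 2. This result is a single step on the butoxy compounds. No supporting data bear on the reason for this result. Still open, as far as these compounds go, is whether an amine or a carboxylic acid at this place would also stay within the scatter. Also open, from the compounds shown here alone, is whether the same methoxy change would read alike with the pentyl group of compound 3.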